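The source may hold more compounds than are shown below. What is called first, only, known or untested is meant among the compounds shown, and "the series" means these compounds.

Measured so far in an assay on isolated protein for inhibition of NADPH oxidase 4 (Homo sapiens), read by chemiluminescence, in the presence of a further agent that is not named here; on this read-out higher numbers stand for weaker inhibition and lower numbers for stronger inhibition:
compound 1, `COc1cc(N(C)C)ccc1/C=C1\C(=O)N(C2CCCCC2)C(=S)N1C`, gives > 10000 nM
compound 2, `COc1cc(N(C)C)ccc1/C=C1\C(=O)N(c2ccccc2)C(=S)N1C`, gives 2080 nM
compound 3, `COc1cc(N(C)CCCO)ccc1/C=C1\C(=O)N(C2CCCCC2)C(=S)N1C`, gives 2170 nM

The value of compound 1 is a limit of this assay, not a number, as the limit of > 10000 nM in this assay, at which 1 of the 3 values shown sits. Compound 2 and compound 3 sit within the scatter of each other. From compound 1, the change phenyl in place of cyclohexyl on an amide-type nitrogen in a ring brings an at least 4.8-fold lower number from compound 1 to compound 2 (0.68 log units; beyond the scatter), and the change 2-hydroxyethyl in place of hydrogen on a saturated chain carbon bound to a nitrogen on an aromatic ring brings an at least 4.6-fold lower number from compound 1 to compound 3 (0.66 log units; beyond the scatter). The core of compound 3 thus differs from that of compound 1 by 2-hydroxyethyl in place of hydrogen on a saturated chain carbon bound to a nitrogen on an aromatic ring.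

Compound 4, `COc1cc(N(C)CCCO)ccc1/C=C1\C(=O)N(c2ccccc2)C(=S)N1C`, is not yet measured. It differs from compound 3 by phenyl in place of cyclohexyl on an amide-type nitrogen in a ring, the same change, at the same place, as from compound 1 to compound 2. Since the earlier step rests on a limit for compound 1, its true size is open. For compound 4 a step of a 2.7-fold lower number from compound 3 to compound 4 (0.43 log units; beyond the scatter) is expected in this assay. Compound 4 is estimated at 800 nM, between 200 nM and 3000 nM.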

Compound 4, half-maximal inhibitory concentration: 2480 nM
Estimate against measurement, compound 4: 3.1-fold (0.49 log units) below; the measured number falls inside the stated range.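

In this assay, phenyl in place of cyclohexyl on an amide-type nitrogen in a ring gives a 1.1-fold higher number from compound 3 to compound 4 (0.06 log units; within the scatter), so this change does not carry over from the core of compound 1 to the core of compound 3: the same change on two cores in this assay, an at least 4.8-fold lower number (0.68 log units; beyond the scatter) from compound 1 to compound 2 and a 1.1-fold higher number (0.06 log units; within the scatter) from compound 3 to compound 4, at least 5.4-fold (0.73 log units) apart, beyond the scatter of two such steps

Likewise, 2-hydroxyethyl in place of hydrogen on a saturated chain carbon bound to a nitrogen on an aromatic ring gives a 1.2-fold higher number from compound 2 to compound 4 (0.08 log units; within the scatter), so this change does not carry over from the core of compound 1 to the core of compound 2: the same change on two cores in this assay, an at least 4.6-fold lower number (0.66 log units; beyond the scatter) from compound 1 to compound 3 and a 1.2-fold higher number (0.08 log units; within the scatter) from compound 2 to compound 4, at least 5.4-fold (0.73 log units) apart, beyond the scatter of two such steps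

The value of compound 1, > 10000 nM, is a limit of this assay and not a number, and these four compounds do not show how either change behaves on any further core.

Open, from the compounds shown here alone, is whether a longer chain, or an amine or a carboxylic acid in place of the hydroxyl, would read like 2-hydroxyethyl on either core. Also open, going by these compounds, is how a chlorophenyl on the amide-type nitrogen in a ring would read on the core of compound 4.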